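The compounds below may be only part of what the source reports. "The series", "measured", "known", "first", "only" and "open" are said of these compounds alone.

Measured in an ADME assay on microsomes from liver (Homo sapiens) for metabolic stability, read by LC-MS, using NADPH, with a stated time of 15 min, tested at 1 uM; a lower number here means slower removal, a higher number faster removal of the compound:
- compound 1 `C[C@@H]1CN(c2sc(C(F)(F)F)nc2-c2nc3ccccc3[nH]2)CCN1C(=O)Cn1cccn1`: 44 mL.min-1.g-1
- compound 2 `Cc1nc(C)n(CC(=O)N2CCN(c3sc(C(F)(F)F)nc3-c3nc4ccc(C5CCOCC5)cc4[nH]3)C[C@H]2C)n1`: 18 mL.min-1.g-1
- compound 3 `Cc1nc(C)n(CC(=O)N2CCN(c3sc(C(F)(F)F)nc3-c3nc4ccc(C(C)(C)O)c(F)c4[nH]3)C[C@H]2C)n1`: < 10 mL.min-1.g-1 (a limit of the assay, not a number)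

Of the two actual numbers in this assay, compound 1, at 44 mL.min-1.g-1, is the higher, and compound 2, at 18 mL.min-1.g-1, lies lower by more than the usual scatter. Compound 3 is reported only as the limit < 10 mL.min-1.g-1.

The next step leads to compound 4 `C[C@@H]1CN(c2sc(C(F)(F)F)nc2-c2nc3ccccc3[nH]2)CCN1C(=O)Cn1cnc2c1CCN(C)C2`, which keeps the core of compound 1 and changes one group, on a saturated chain carbon bound to a carbonyl carbon: a group of 10 heavy atoms (7 carbon, 3 nitrogen; one five-membered aromatic ring with 2 hetero atoms, one six-membered non-aromatic ring with 1 hetero atom) in place of a group of 5 heavy atoms (3 carbon, 2 nitrogen; one five-membered aromatic ring with 2 hetero atoms), on a saturated chain carbon bound to a carbonyl carbon. The 1H-pyrazol-1-yl group leaves, and the group that enters adds a six-membered non-aromatic ring with 1 hetero atom to its five-membered aromatic ring with 2 hetero atoms.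

For the measured compounds named here, no measured pair isolates this change, since compound 2 and compound 3 each differ from compound 1 in more than one place. A small downward move in this assay is expected, quite possibly not beyond the usual scatter, and this lean rests only on compound 2 at 18 mL.min-1.g-1. The expected change is a 1.3-fold lower number from compound 1 to compound 4 (0.11 log units; within the scatter). For compound 4 the estimated value is 34 mL.min-1.g-1, with an expected range from 15 mL.min-1.g-1 to 75 mL.min-1.g-1.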

Compound 4, intrinsic clearance in microsomes: 21 mL.min-1.g-1
Beside the measured number, compound 4's estimate is 1.6-fold (0.21 log units) above it, within the range that was stated.
By their numbers in this assay, from the lowest: compounds 2 and 4 (each within the scatter of the next); then compound 1. At a limit, below all of these: compound 3.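

In this assay, the larger group on the saturated chain carbon bound to a carbonyl carbon gives a 2.1-fold lower number from compound 1 to compound 4 (0.32 log units; beyond the scatter), a modest step. For the compounds shown here, with the core of compound 1 held unchanged, this is the first comparison here that isolates this position, and it shows that the number in this assay moves with the group at this place alone. It also shows that adding a six-membered non-aromatic ring with 1 hetero atom to the five-membered aromatic ring with 2 hetero atoms goes with slower removal rather than faster, although the group entering is the larger one, but nothing in the data shown accounts for this step.

From the compounds shown here alone, the step changes the ring content and the size of the group together, and it remains open whether the added ring as a whole or its hetero atom goes with the lower number, or whether an open-chain amine or a carboxylic acid on the same carbon would give a similar step. Going by these compounds, it also remains open whether the same change would give a similar step on the substituted cores of compound 2 and compound 3.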